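Fluorine for Chlorine in a Small Stilbene Amide Set

This account rests on a few compounds, and the source may have more. Where it says the series, first, only, none or still open, it means among the compounds named here.

The study covers four compounds on one shared core: compound 1 `COc1ccc(C(N)=O)cc1/C=C/c1ccccc1F`, compound 2 `COc1ccc(C(N)=O)cc1/C=C/c1ccccc1Cl`, compound 3 `COc1ccc(C(N)=O)cc1/C=C/c1ccc(Cl)cc1Cl` and the still unmeasured compound 4 `COc1ccc(C(N)=O)cc1/C=C/c1ccc(Cl)cc1F`.

In an ADME assay on HCT-116 cells (Homo sapiens) for antiproliferative activity (on this read-out higher numbers stand for weaker inhibition and lower numbers for stronger inhibition), compound 1 gives 26000 nM. Compound 2 reaches only a limit of the assay, > 50000 nM. Compound 3 likewise reaches only a limit of the assay, > 50000 nM. The change from compound 2 to compound 1 is fluoro in place of chloro on an aromatic carbon and it produced an at least 1.9-fold lower number from compound 2 to compound 1 (0.28 log units; that floor lies within the scatter). The cores of compound 2 and compound 3 differ by chloro in place of hydrogen on an aromatic carbon, and that change made a step that the two limits leave unreadable from compound 2 to compound 3 because the limit of > 50000 nM in this assay, at which 2 of the 3 values shown sit, covers both of those values.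

Compound 4 differs from compound 3 by fluoro in place of chloro on an aromatic carbon. For the measured compounds named here, this is the same kind of change as the one from compound 2 to compound 1, though the place is not identical: in compound 4 it is ortho to a large group and also meta to a chloro group, whereas in compound 1 it is only ortho to a large group. Resting on that single earlier step, compound 4 is expected to show an at least 1.2-fold lower number from compound 3 to compound 4 (0.09 log units; that floor lies within the scatter). Compound 4 is accordingly estimated at 40000 nM in this assay, with a likely span from 15000 nM to 100000 nM, and a result that again stops at the limit of the assay is judged roughly as likely as a readable number. Whether the fluoro group pulls compound 4 off that limit is what the measurement will show.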

Compound 4, half-maximal inhibitory concentration: > 10000 nM
Compound 4: no number, only a limit; the forecaster's own chance of this, stated with the estimate: 55%; the middle value does not contradict the limit.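

In this assay compound 4 reaches only a limit of the assay, > 10000 nM. Neither the step from compound 3 to compound 4 nor the step from compound 1 to compound 4 can be read, since neither has a number for compound 4 to rest on: the limit of > 10000 nM in this assay, at which 1 of the 4 values shown sits. The compounds shown leave open how far fluoro in place of chloro on an aromatic carbon moves the read-out when a chloro group is also present.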